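Cytotoxicity notes: bromo to methyl on the aryl ring

The source may report more compounds than this note shows. Statements on the series, on what has been measured and on what is new or still open speak of the compounds shown alone.

Measured so far:
compound 1 `Brc1ccc(-c2cc(COc3ccccc3-c3nc4ccccc4s3)on2)cc1`: 19200 nM
compound 2 `c1ccc(-n2cc(COc3ccccc3-c3nc4ccccc4s3)nn2)cc1`: 16400 nM

In a functional assay on A549 cells (Homo sapiens) for cytotoxicity, read by MTT assay, with a stated time of 24 h (on this read-out lower numbers stand for stronger inhibition and higher numbers for weaker inhibition), compound 1 gives 19200 nM, the highest of the two numbers; compound 2 gives 16400 nM, a gap that lies within the scatter. Compound 3 `Cc1ccc(-c2cc(COc3ccccc3-c3nc4ccccc4s3)on2)cc1` is not yet measured. It differs from compound 1 by methyl in place of bromo on an aromatic carbon. Within the data shown here, no measured pair shows this change, so no size can be read off; the expected step of a 1.1-fold higher number from compound 1 to compound 3 (0.06 log units; within the scatter) is none beyond the scatter. Compound 3 is estimated at 22000 nM, in the range 9000 nM to 55000 nM.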

Compound 3, half-maximal inhibitory concentration: 16400 nM
For compound 3 the middle estimate is 1.3-fold (0.13 log units) above the measured one; measured number inside the range.
By their numbers in this assay, from the lowest: compounds 2, 3 and 1 (each within the scatter of the next).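

Among these compounds, this is the first pair that differs in one place. In this assay the move from 4-bromophenyl to 4-methylphenyl gives a 1.2-fold lower number from compound 1 to compound 3 (0.07 log units; within the scatter) and so the two groups cannot be told apart at this position on the shared core. Nothing at hand bears on why the two read alike.

From the compounds shown here alone, whether this holds for a group of another kind at the same position stays open, such as an amine, a carboxylic acid or a longer chain. One pair also leaves open whether the same swap reads alike on the core of compound 2.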